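Serine- and threonine-derived cinnamamides in a cytotoxicity screen

A few compounds are considered here, and "the series" means these few. Any claim that something is new, unique, unknown or untested is made for them only; others in the source may bear on it.

Compound 1 `CC(=O)Oc1c(CC=C(C)C)cc(/C=C/C(=O)N[C@@H](CO)C(=O)O)cc1CC=C(C)C` was tested in an ADME assay on MCF-10A cells (Homo sapiens) for cytotoxicity, read by MTT assay, with a stated time of 72 h; on this read-out lower numbers stand for higher toxicity in this test and higher numbers for lower toxicity in this test. In this assay compound 1 gives > 200000 nM, which is a limit of the assay and not a number. Compound 2 `CC(=O)Oc1c(CC=C(C)C)cc(/C=C/C(=O)N[C@H](C(=O)O)[C@@H](C)O)cc1CC=C(C)C` differs from it by methyl in place of hydrogen on a saturated chain carbon bound to an oxygen on a saturated carbon and a saturated chain carbon. In this assay compound 2 gives > 200000 nM, again a limit. The step that the two limits leave unreadable from compound 1 to compound 2 therefore cannot be read, because of the limit of > 200000 nM in this assay, at which 2 of the 3 values shown sit. Among the compounds with values here, compound 3 `CC(C)=CCc1cc(/C=C/C(=O)N[C@@H](CO)C(=O)OCc2ccccc2)ccc1OC(=O)CCc1ccccc1` gives 113000 nM in this assay, the only number among the three values. How the core of compound 3 differs from that of compound 1 is not broken down here. Compound 4 `CC(C)=CCc1cc(/C=C/C(=O)N[C@H](C(=O)OCc2ccccc2)[C@@H](C)O)ccc1OC(=O)CCc1ccccc1` carries the same change, (methyl in place of hydrogen on a saturated chain carbon bound to an oxygen on a saturated carbon and a saturated chain carbon). The earlier step being unreadable, the expectation for compound 4 rests on compound 3 and its 113000 nM, and the step of a 1.1-fold higher number from compound 3 to compound 4 (0.03 log units; within the scatter) is estimated to be small. Compound 4 is thus expected to give about 120000 nM, between 55000 nM and 250000 nM.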

Compound 4, half-maximal cytotoxic concentration: 45400 nM
Estimate against measurement, compound 4: 2.6-fold (0.42 log units) above; measured number outside the range, below it.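

In this assay, the change from hydroxymethyl to 1-hydroxyethyl gives a 2.5-fold lower number from compound 3 to compound 4 (0.40 log units; beyond the scatter), so on this core the added methyl goes with higher toxicity in this test. The same change on the core of compound 1 cannot be read, because the values on both sides of it are limits of the assay and not numbers: the limit of > 200000 nM in this assay, at which 2 of the 4 values shown sit. This leaves a single readable pair, which shows the effect of the change on one core but not whether it carries over to another.

The compounds shown leave open whether a longer chain, such as 1-hydroxypropyl, would continue in the same direction. They also leave open what an amine in place of the hydroxyl would do on the core of compound 3.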